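Carbonyl substituent variation in the furyl series

A few compounds are considered here, and "the series" means these few. Any claim that something is new, unique, unknown or untested is made for them only; others in the source may bear on it.

Compound 1 `COc1cc(-c2nnc3n2NC(c2ccco2)C(C(=O)c2cccs2)S3)cc(OC)c1OC` gives 46200 nM in a functional assay on PC-3 cells (Homo sapiens) for cytotoxicity, read by MTT assay, with a stated time of 48 h; a lower number here means a stronger inhibitor, a higher number a weaker inhibitor. Compound 2 `COc1cc(-c2nnc3n2NC(c2ccco2)C(C(=O)c2ccccc2)S3)cc(OC)c1OC` gives 64300 nM and compound 3 `COc1cc(-c2nnc3n2NC(c2ccco2)C(C(=O)c2ccc(F)c(F)c2)S3)cc(OC)c1OC` gives 36000 nM in this assay. All three numbers fall within the scatter of one another; compound 1 lies among them, with compound 3 nearest and compound 2 furthest. Compound 4 `COc1cc(-c2nnc3n2NC(c2ccco2)C(C(=O)c2ccc(-c4ccccc4)cc2)S3)cc(OC)c1OC` differs from compound 1 only at the group on the carbonyl carbon: 4-phenylphenyl in place of thiophen-2-yl on a carbonyl carbon. For the measured compounds named here, the steps seen at this position so far were a 1.4-fold higher number from compound 1 to compound 2 (0.14 log units; within the scatter), a 1.3-fold lower number from compound 1 to compound 3 (0.11 log units; within the scatter) and a 1.8-fold lower number from compound 2 to compound 3 (0.25 log units; within the scatter), none beyond the scatter. From the compounds shown here alone, whether 4-phenylphenyl behaves like the groups tried so far is untested, but on this record the expected step is a 1.1-fold lower number from compound 1 to compound 4 (0.04 log units; within the scatter), with no direction beyond the scatter. Compound 4 is therefore estimated at 42000 nM, within 15000 nM to 120000 nM.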

Compound 4, half-maximal inhibitory concentration: 45900 nM
Beside the measured number, compound 4's estimate is 1.1-fold (0.04 log units) below it; the measured number falls inside the stated range.
By their numbers in this assay, from the lowest: compounds 3, 4, 1 and 2 (each within the scatter of the next).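

With 4-phenylphenyl in place of thiophen-2-yl on a carbonyl carbon, this assay gives a 1.0-fold lower number from compound 1 to compound 4 (0.00 log units; within the scatter) and so extends the flat record at this position to a group of two six-membered aromatic rings. The step to the 3,4-difluorophenyl compound, a 1.3-fold higher number from compound 3 to compound 4 (0.11 log units; within the scatter) in reverse direction of listing aside, also stays within the scatter. Phenyl in place of hydrogen on an aromatic carbon gives a 1.4-fold lower number from compound 2 to compound 4 (0.15 log units; within the scatter) and likewise stays within the scatter. From the compounds shown here alone, whether an amine or a carboxylic acid on the carbonyl carbon would move the number beyond the scatter stays open. No evidence on hand accounts for the flat response at this position.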